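Furyl Thiosemicarbazone Variant of a Terpenyl Isothiocyanate

The source may hold more compounds than are shown below. What is called first, only, known or untested is meant among the compounds shown, and "the series" means these compounds.

Compound 1 `CC1=CC[C@H](C(C)(C)N=C=S)CC1`: > 100000 nM
Compound 2 `COc1ccc(/C=N/NC(=S)NC(C)(C)[C@H]2CC=C(C)CC2)cc1`: 22500 nM

In a functional assay on NCI-H460 cells (Homo sapiens) for inhibition, read by sulforhodamine B assay, with a stated time of 48 h (a higher number here means a weaker inhibitor of growth, a lower number a stronger inhibitor of growth), compound 1 gives only a limit, > 100000 nM. Among the compounds with values here, compound 2 gives 22500 nM in this assay, the only actual number among the two values shown. The other entry is the limit of > 100000 nM in this assay, at which 1 of the 2 values shown sits. Compound 3 `CC1=CC[C@H](C(C)(C)NC(=S)N/N=C/c2ccco2)CC1` is still unmeasured. It differs from compound 2 by furan-2-yl in place of 4-methoxyphenyl on a carbon with a double bond to nitrogen. Within the data shown here, no measured step speaks to this change, so compound 3 is expected to stay close to compound 2, with a step of a 1.3-fold higher number from compound 2 to compound 3 (0.12 log units; within the scatter), not beyond the usual scatter. Compound 3 is therefore estimated at 30000 nM, between 8000 nM and 100000 nM.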

Compound 3, concentration for 50% growth inhibition: 13500 nM
The estimate for compound 3 lay 2.2-fold (0.35 log units) above the measured number, within the range that was stated.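

In this assay, furan-2-yl in place of 4-methoxyphenyl on a carbon with a double bond to nitrogen gives a 1.7-fold lower number from compound 2 to compound 3 (0.22 log units; within the scatter). Compound 2 and compound 3 therefore cannot be told apart, so this place accepts a five-membered aromatic ring with 1 hetero atom as well as a six-membered aromatic ring of carbon only. Nothing measured here bears on a cause for this result. The compounds shown leave open whether a pyridine ring, an amine or a longer alkyl chain at this place would keep this level of growth inhibition. They also leave open how a carboxylic acid there would read.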